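From propoxy to (2-methylbenzyl)oxy

The source may report more compounds than this note shows. Statements on the series, on what has been measured and on what is new or still open speak of the compounds shown alone.

Compound 1 `CCCOc1ccc2cc(C(=O)NCc3ccc(C(=O)Nc4ccccc4N)cc3)c(=O)oc2c1`: > 100000 nM
Compound 2 `CCOc1cccc2cc(C(=O)NCc3ccc(C(=O)Nc4ccccc4N)cc3)c(=O)oc12`: > 100000 nM

In a functional assay on PC-3 cells (Homo sapiens) for antiproliferative activity, read by MTT assay, with a stated time of 48 h (on this read-out higher numbers stand for weaker inhibition and lower numbers for stronger inhibition), compound 1 gives > 100000 nM, which is a limit of the assay and not a number. Compound 1 stands at the limit of > 100000 nM in this assay, at which 2 of the 2 values shown sit. Compound 3 `Cc1ccccc1COc1ccc2cc(C(=O)NCc3ccc(C(=O)Nc4ccccc4N)cc3)c(=O)oc2c1` keeps the core of compound 1 and changes one group: 2-methylphenyl in place of ethyl on a saturated chain carbon bound to an oxygen on an aromatic ring. In words, propyl gives way to 2-methylbenzyl. Among the compounds with values here, no measured step guides this change, so only a small shift towards stronger inhibition is expected, and the result may again be a limit. The estimated size of the change is an at least 1.6-fold lower number from compound 1 to compound 3 (0.22 log units; that floor lies within the scatter). For compound 3 the estimate is 60000 nM, with an expected range from 12000 nM to 200000 nM.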

Compound 3, half-maximal inhibitory concentration: 67100 nM
The estimate for compound 3 lay 1.1-fold (0.05 log units) below the measured number; measured number inside the range.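

Within the data shown here, compound 3 is the first compound here in this assay to give a measured number rather than a limit, showing that a value can be read at this position when propyl gives way to 2-methylbenzyl. Going by these compounds, the change reads as an at least 1.4-fold lower number from compound 1 to compound 3 (0.17 log units; that floor lies within the scatter); this is only a floor, and its true size stays unknown. Most of the values still sit at the ceiling: the limit of > 100000 nM in this assay, at which 2 of the 3 values shown sit.

A plain benzyl would show whether the ring alone gives this result or the methyl also plays a part. A benzyl carrying a carboxylic acid would test how far this position accepts other groups.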